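The compounds below may be only part of what the source reports. "The series", "measured", "known", "first", "only" and "open" are said of these compounds alone.

Compounds measured in a functional assay on PBMC cells (Homo sapiens) for inhibition, read by ELISA, with a stated time of 18 h; on this read-out lower numbers stand for stronger inhibition and higher numbers for weaker inhibition:
compound 1, `CCCCSC(=S)C1=C(Nc2ccc(Cl)cc2Cl)CC(C)(C)CC1=O`: > 20 ug/mL
compound 2, `CCCCSC(=S)C1=C(Nc2ccc(Cl)cc2)CC(C)(C)CC1=O`: > 20 ug/mL
compound 3, `CC1(C)CC(=O)C=C(Nc2ccc(Br)cc2)C1`: > 20 ug/mL

Each of these three values is a limit of this assay rather than a number, and all of them sit at the limit of > 20 ug/mL in this assay, at which 3 of the 3 values shown sit. Compound 3 thus stands only at a limit. The two other values shown are limits as well, so no ordering among the three compounds can be read. Within the data shown here, the single step between measured compounds, a step that the two limits leave unreadable from compound 1 to compound 2, is left unreadable by the two limits.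

Compound 4, `CCCCSC(=S)C1=C(Nc2ccc(Br)cc2)CC(C)(C)CC1=O`, is to be measured in this assay. It differs from compound 3 by a group of 7 heavy atoms (5 carbon, 2 sulfur; no ring) in place of a hydrogen atom, on a double-bonded ring carbon. Among the measured compounds shown here, the same entering group is already present in compound 1 and in compound 2, each of which returns only a limit, and the one measured step gives no readable size for any change. No step beyond the scatter is therefore expected from compound 3 to compound 4. The step that the limit leaves unreadable from compound 3 to compound 4 is the estimate that follows, resting mainly on the likelihood of another limit. Compound 4 is expected to give about 30 ug/mL, within 8 ug/mL to 100 ug/mL.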

Compound 4, half-maximal inhibitory concentration: > 20 ug/mL
Compound 4 was reported as a limit (the forecaster's own chance of this, stated with the estimate: 80%); the middle value is on the limit's open side.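

In this assay compound 4 gives > 20 ug/mL, a limit of the assay. The steps from compound 1, compound 2 and compound 3 to compound 4 cannot be read: the limit of > 20 ug/mL in this assay, at which 4 of the 4 values shown sit.

The compounds shown leave open whether any change in this series alters inhibition in this assay.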